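From a Butyl Chain to a Dimethylamino Chain

A few compounds are considered here, and "the series" means these few. Any claim that something is new, unique, unknown or untested is made for them only; others in the source may bear on it.

Measured in a functional assay on P388 cells (Mus musculus) for cytotoxicity; on this read-out lower numbers stand for stronger inhibition and higher numbers for weaker inhibition:
- compound 1 `O=C1c2cccc3c2c(cc2c4ccccc4sc32)C(=O)N1CN1CCNCC1`: 72400 nM
- compound 2 `CCCCN1C(=O)c2cccc3c2c(cc2c4ccccc4sc32)C1=O`: 740 nM
- compound 3 `CCCCN1C(=O)c2cccc3c2c(cc2c4ccccc4oc32)C1=O`: > 100000 nM (a limit)

Compound 2 has the lower of the two exact numbers, and the value for compound 3 is only a limit. Compound 4 `CN(C)CCCN1C(=O)c2cccc3c2c(cc2c4ccccc4sc32)C1=O` changes the butyl chain of compound 2: dimethylamino in place of methyl on a saturated chain carbon, three bonds along the chain from an amide-type nitrogen in a ring. This places dimethylamino in place of methyl on a saturated chain carbon, three bonds along the chain from an amide-type nitrogen in a ring. The nearest measured change is a 98-fold lower number from compound 1 to compound 2 (1.99 log units; beyond the scatter). That large step involves piperazin-1-yl rather than dimethylamino, so it sets no firm direction here. In this assay, the estimated change is a 1.1-fold lower number from compound 2 to compound 4 (0.02 log units; within the scatter), which is not expected to exceed the scatter. Compound 4 is expected at 700 nM, with an estimated range of 70 nM to 7000 nM.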

Compound 4, half-maximal inhibitory concentration: 320 nM
The estimate for compound 4 lay 2.2-fold (0.34 log units) above the measured number; measured number inside the range.
By their numbers in this assay, from the lowest: compound 4; then compound 2; then compound 1. At a limit, above all of these: compound 3.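

In this assay, placing dimethylamino on this chain carbon gave a 2.3-fold lower number from compound 2 to compound 4 (0.36 log units; beyond the scatter), so the end of the butyl chain accepts this group with a modest gain, beyond the scatter. The full 3-(dimethylamino)propyl chain also gave a 230-fold lower number from compound 1 to compound 4 (2.35 log units; beyond the scatter), the largest step seen so far at this ring nitrogen. Nothing measured here accounts for the gain.

The compounds shown leave open whether a longer chain ending in dimethylamino, or a primary amine at the same place, would lower the number further. They also leave open whether the 3-(dimethylamino)propyl chain would change the picture on the core of compound 3, whose value is only a limit.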